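A few compounds are considered here, and "the series" means these few. Any claim that something is new, unique, unknown or untested is made for them only; others in the source may bear on it.

Working notes on the series

Three compounds of the series have been run in a functional assay on MDA-MB-231 cells (Homo sapiens) for antiproliferative activity, read by sulforhodamine B assay, with a stated time of 48 h; on this read-out higher numbers stand for weaker inhibition and lower numbers for stronger inhibition. Compound 1 `COc1ccc2nc(-c3ccc(N/C=C\C(=O)c4ccc(OC)c([N+](=O)[O-])c4)cc3)sc2c1` gives 17600 nM. Compound 2 `COc1ccc2nc(-c3ccc(N/C=C\C(=O)c4ccc(OC)c([N+](=O)[O-])c4)c(C)c3)sc2c1` gives 17600 nM. These two differ in one place, (hydrogen in place of methyl on an aromatic carbon), and the step of no change at the digits printed from compound 2 to compound 1 (within the scatter). Compound 3 `COc1cc(C(=O)/C=C\Nc2ccc(-c3nc4cc(OC)c(OC)c(OC)c4s3)cc2C)cc(OC)c1OC` gives 12900 nM; set against compound 1 and compound 2 it lies within the scatter of both, so no order among the three is read from these numbers. The difference between the core of compound 3 and the core of compound 2 is not broken down here.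

Compound 4 `COc1cc(C(=O)/C=C\Nc2ccc(-c3nc4cc(OC)c(OC)c(OC)c4s3)cc2)cc(OC)c1OC` has not yet been measured. It differs from compound 3 as hydrogen in place of methyl on an aromatic carbon. This is the same kind of change as from compound 2 to compound 1, not the same one: around the site in compound 3 the group in the meta position is given only as a large group, whereas in compound 2 it is a 6-methoxy-1,3-benzothiazol-2-yl group.

In this assay compound 4 is expected to give about 13000 nM, with a range from 6000 nM to 28000 nM. Going by the values given here, the expected step of a 1.0-fold higher number from compound 3 to compound 4 (0.00 log units; within the scatter) rests on the one precedent, the step from compound 2 to compound 1, which was within the scatter no change at the digits printed from compound 2 to compound 1 (within the scatter); with a single precedent the range is kept wide.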

Compound 4, half-maximal inhibitory concentration: 16500 nM
Compound 4: the middle estimate sits 1.3-fold (0.10 log units) below what was measured, and the stated range covers the measured number.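

Hydrogen in place of methyl on the aromatic carbon gives, in this assay, a 1.3-fold higher number from compound 3 to compound 4 (0.11 log units; within the scatter), so on the second core this change again leaves no step that can be read. Set beside the earlier step, the change carries from one core to the other without a readable difference: the same change on two cores in this assay, no change at the digits printed (within the scatter) from compound 2 to compound 1 and a 1.3-fold higher number (0.11 log units; within the scatter) from compound 3 to compound 4, 1.3-fold (0.11 log units) apart, within the scatter of two such steps. This agreement rests on two cores only and shows that the change stayed within the scatter on both; it does not show that the same would hold on a further core, and it gives no step size to carry over, as neither step can be told apart from no change.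

The compounds shown leave open whether another group on this aromatic carbon, such as a chlorine atom, a methoxy group or an amine, would move the number beyond the scatter on either core. They also leave open which parts of the two cores bear on the read-out, as compound 1 and compound 4 differ in more than one place and no single change between them can be read from these values.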